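A few compounds are considered here, and "the series" means these few. Any claim that something is new, unique, unknown or untested is made for them only; others in the source may bear on it.

Measured so far in a functional assay on MCF-10A cells (Homo sapiens) for antiproliferative activity, with a stated time of 48 h; a higher number here means that more compound is needed for the effect, a lower number that less compound is needed:
Compound 1 `COc1ccc2nc(C)cc(NCc3ccccc3)c2c1` gives 28600 nM
Compound 2 `COc1ccc2nc(C)cc(NCc3ccccc3OC)c2c1` gives 29500 nM
Compound 3 `COc1ccc2nc(C)cc(NCc3ccc(N(C)C)cc3)c2c1` gives 20000 nM

Compound 1 stands among these three numbers with both of the others within the scatter of it, so no order can be read from them. Compound 4 `COc1ccc2nc(C)cc(NCc3cccc(C#N)c3)c2c1` has not yet been measured and differs from compound 1 by cyano in place of hydrogen on an aromatic carbon (cyano in place of hydrogen on an aromatic carbon, meta to a large group). For the measured compounds named here, two measured steps bear on this change. The step of a 1.0-fold higher number from compound 1 to compound 2 (0.01 log units; within the scatter) comes with methoxy in place of hydrogen on an aromatic carbon, and the step of a 1.4-fold lower number from compound 1 to compound 3 (0.16 log units; within the scatter) comes with dimethylamino in place of hydrogen on an aromatic carbon. Neither step introduces cyano, so they guide the expectation only loosely. Even so, no step beyond the scatter is expected in this assay, in either direction. What is expected is a 1.1-fold lower number from compound 1 to compound 4 (0.06 log units; within the scatter) in this estimate, with no direction to be relied on. For compound 4 the estimated value is 25000 nM (expected range 12000 nM to 50000 nM).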

Compound 4, half-maximal effective concentration: 17400 nM
Compound 4: middle estimate off by 1.4-fold (0.16 log units), on the high side; the measured number falls inside the stated range.
By their numbers in this assay, from the lowest: compounds 4, 3, 1 and 2 (each within the scatter of the next).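

In this assay, cyano on an aromatic carbon, meta to a large group, gives a 1.6-fold lower number from compound 1 to compound 4 (0.22 log units; within the scatter), so this place on the six-membered aromatic ring takes a group with a triple bond and the number stays within the scatter of compound 1. Compound 4 thus joins compound 2 and compound 3: none of the three groups added to compound 1 gives a step beyond the scatter, and no direction can be read from this one. Nothing available here speaks to what lies behind this step.

On these data alone, whether a carboxylic acid, an amine or a longer chain at this place would move the number beyond the scatter remains open. So does whether cyano at another place on the ring would behave as it does here.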